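Aryl substituent changes on the shared core

The source may report more compounds than this note shows. Statements on the series, on what has been measured and on what is new or still open speak of the compounds shown alone.

In a functional assay on MDA-MB-231 cells (Homo sapiens) for cytotoxicity, read by MTT assay, with a stated time of 48 h (a lower number here means a stronger inhibitor, a higher number a weaker inhibitor), compound 2 `Cc1cccc(NC(=O)NCCCCC(c2ccc(F)cc2)c2ccc(F)cc2)c1` gives only a limit, > 20000 nM. Compound 1 `O=C(OCCCC(c1ccc(F)cc1)c1ccc(F)cc1)c1cc(Cl)c(OCc2ccccc2)c(Cl)c1` likewise gives only a limit, > 20000 nM. Compound 3 `O=C(NCCCCC(c1ccc(F)cc1)c1ccc(F)cc1)Nc1ccc([N+](=O)[O-])c(C(F)(F)F)c1` gives a number, 4550 nM. Within the data shown here, compound 2 thus sits at the limit of > 20000 nM in this assay, at which 2 of the 3 values shown sit, and compound 3 is the one number among the three. Compound 4 `O=C(NCCCCC(c1ccc(F)cc1)c1ccc(F)cc1)Nc1ccc(Br)cc1I` differs from compound 2 by 4-bromo-2-iodophenyl in place of 3-methylphenyl on an amide-type nitrogen. Among the measured compounds shown here, no measured step connects the two, and with compound 2 at a limit the step cannot be sized from compound 2 alone. Compound 3 shows that another substituent on the amide-type nitrogen gives 4550 nM. The expected step from compound 2 to compound 4 is an at least 2.2-fold lower number from compound 2 to compound 4 (0.34 log units; beyond the scatter), toward stronger inhibition. Compound 4 is estimated at 9000 nM, within 3000 nM to 25000 nM, with a real chance of only a limit.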

Compound 4, half-maximal inhibitory concentration: > 20000 nM
Compound 4: only a limit was reported; the forecaster's own chance of this, stated with the estimate: 40%; at least 2.2-fold (0.34 log units) between middle value and limit.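

Compound 2 and compound 4 both give only a limit, so no step between them can be read: the limit of > 20000 nM in this assay, at which 3 of the 4 values shown sit.

As far as these compounds go, whether 4-bromo-2-iodophenyl and 3-methylphenyl on the amide-type nitrogen differ at all in this assay stays open.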